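The compounds below may be only part of what the source reports. "The series", "measured", "known", "first", "only" and "open" are said of these compounds alone.

Working notes on the series. In a functional assay on HT-29 cells (Homo sapiens) for antiproliferative activity, read by MTT assay, with a stated time of 72 h (on this read-out higher numbers stand for weaker inhibition and lower numbers for stronger inhibition), compound 1 `C=CC(=O)Nc1nc(-c2ccccc2)cs1` gives 6600 nM. Compound 3 `C=CC(=O)Nc1nc(-c2ccc(C)cc2)cs1` gives 16100 nM, the higher of the two numbers in hand. The step between them is a 2.4-fold higher number from compound 1 to compound 3 (0.39 log units; beyond the scatter), for methyl in place of hydrogen on an aromatic carbon.

Compound 2 `C=CC(=O)Nc1sc(-c2ccccc2)cc1C(=O)OCC` reads > 30000 nM, which is a limit of the assay and not a number.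

Compound 4 `C=CC(=O)Nc1nc(-c2ccc(C(F)(F)F)cc2)cs1` has trifluoromethyl in place of methyl on an aromatic carbon, para to a large group (trifluoromethyl in place of methyl on an aromatic carbon). For the measured compounds named here, no measured step replaces methyl itself, and only the modest step from hydrogen to methyl bears on this change. Resting on a 2.4-fold higher number from compound 1 to compound 3 (0.39 log units; beyond the scatter) as the sole precedent, a small step in this assay is expected, upward if anything and not beyond the scatter. The expected step is a 1.1-fold higher number from compound 3 to compound 4 (0.05 log units; within the scatter). A reading reported only as a limit remains possible. For compound 4 the estimated value is 18000 nM, with an expected range from 8000 nM to 30000 nM.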

Compound 4, half-maximal inhibitory concentration: 4000 nM
Beside the measured number, compound 4's estimate is 4.5-fold (0.65 log units) above it; the whole stated range lies above it.
By their numbers in this assay, from the lowest: compounds 4 and 1 (each within the scatter of the next); then compound 3. At a limit, above all of these: compound 2.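

On this aromatic carbon, para to a large group, substitution in this assay does not follow one direction: methyl gave a 2.4-fold higher number from compound 1 to compound 3 (0.39 log units; beyond the scatter) in the earlier step, whereas trifluoromethyl in place of methyl now gives a 4.0-fold lower number from compound 3 to compound 4 (0.60 log units; beyond the scatter) and so reverses that rise. Read against the unsubstituted compound, trifluoromethyl in place of hydrogen gives a 1.7-fold lower number from compound 1 to compound 4 (0.22 log units; within the scatter) and stays within the scatter, so this position accepts trifluoromethyl with no change that can be told from repeat measurement, and of the two groups only methyl moves the number beyond the scatter. Nothing measured in this set of compounds accounts for the different readings of methyl and trifluoromethyl at this position.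

From the compounds shown here alone, whether a chlorine, a methoxy group or an amine on this aromatic carbon would read with compound 3 or with compound 1 and compound 4 remains open. Also open, going by these compounds, is whether trifluoromethyl would change the reading on the core of compound 2, which stands at > 30000 nM as a limit of the assay and not a number.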